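The source may hold more compounds than are shown below. What is called first, only, known or untested is meant among the compounds shown, and "the series" means these compounds.

Measured so far:
compound 1 `ClCc1ccc(Cn2cnc3c(Cl)ncnc32)cc1` — 7410 nM
compound 2 `ClCc1cccc(Cn2cnc3c(Cl)nc(Cl)nc32)c1` — 10000 nM
compound 3 `Nc1nc(Cl)c2ncn(Cc3ccccc3CCl)c2n1` — 10000 nM

In a functional assay on NCI-H226 cells (Homo sapiens) for cytotoxicity, read by sulforhodamine B assay, with a stated time of 48 h (a lower number here means a stronger inhibitor of growth, a higher number a weaker inhibitor of growth), compound 1 gives the lowest of the three numbers, yet compound 2 and compound 3 both sit within the usual scatter of it, so the three cannot be told apart. Compound 4 `ClCc1ccc(Cn2cnc3c(Cl)nc(Cl)nc32)cc1` has not been measured. It differs from compound 1 by chloro in place of hydrogen on an aromatic carbon, the chloro entering between two ring nitrogen atoms of the shared core. Among the measured compounds shown here, no pair of measured compounds differing in one place is available, so the size of this step is not known from the data. Compound 2 carries the same chloro on its core and gives 10000 nM, which suggests no movement beyond the scatter. Compound 4 is therefore expected to give 9000 nM, between 4000 nM and 20000 nM, a step of a 1.2-fold higher number from compound 1 to compound 4 (0.08 log units; within the scatter) from compound 1.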

Compound 4, concentration for total growth inhibition: 9550 nM
Beside the measured number, compound 4's estimate is 1.1-fold (0.03 log units) below it, within the range that was stated.
By their numbers in this assay, from the lowest: compounds 1, 4, 2 and 3 (each within the scatter of the next).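

In this assay, among the compounds shown here, chloro in place of hydrogen on an aromatic carbon, between two ring nitrogen atoms, gives a 1.3-fold higher number from compound 1 to compound 4 (0.11 log units; within the scatter) and is the first step that can be read in one place. For the compounds shown here, this position therefore accepts the chloro without a movement beyond the scatter, which the earlier compounds could only suggest. No evidence bears on this step. The compounds shown leave open what a methoxy group or a carboxylic acid would do at this position. They also leave open whether any group there would move the number beyond the scatter.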